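A few compounds are considered here, and "the series" means these few. Any claim that something is new, unique, unknown or untested is made for them only; others in the source may bear on it.

Values in an ADME assay (liver) for metabolic stability, with Liver microsome (Homo sapiens) as the target, read by LC-MS, using microsomes and NADPH, with a stated time of 5 min, at 37 degrees C (a higher number here means faster removal of the compound, a lower number slower removal), so far:

- compound 1 `CCn1c([C@@H](C)NS(=O)(=O)c2ccc(Cl)cc2)nc2ccc(CO)cc21` gives 84 mL.min-1.g-1
- compound 2 `CCn1c(C(C)NS(=O)(=O)c2ccc(Cl)cc2)nc2cnccc21` gives 35 mL.min-1.g-1
- compound 3 `CCn1c([C@@H](C)NS(=O)(=O)c2cccc(C#N)c2)nc2ccc(C(F)(F)F)cc21` gives > 100 mL.min-1.g-1 (a limit, not a number)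

Compound 3 gives > 100 mL.min-1.g-1, which is a limit of this assay and not a number. It therefore has no exact place in the series. The record shows it as the limit of > 100 mL.min-1.g-1 in this assay, at which 1 of the 3 values shown sits, and only compound 1 and compound 2 carry true numbers.

The next compound is compound 4 `CCCn1ncc(S(=O)(=O)N[C@H](C)c2nc3ccc(C(F)(F)F)cc3n2CC)c1C`. Its structure departs from compound 3 in one place, with 5-methyl-1-propyl-1H-pyrazol-4-yl in place of 3-cyanophenyl on a sulfonyl sulfur. The rest of the structure is unchanged.

Among the compounds with values here, no measured pair differs in one place only, so this exchange has no direct precedent. The starting point is also only a limit, which leaves any forecast loose. In this assay the estimated change an at least 1.3-fold lower number from compound 3 to compound 4 (0.12 log units; that floor lies within the scatter) is a modest fall, and a result that again reaches the limit would not be surprising.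

For compound 4 the estimated value is 75 mL.min-1.g-1, with an expected range of 35 mL.min-1.g-1 to 130 mL.min-1.g-1.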

Compound 4, intrinsic clearance in microsomes: > 100 mL.min-1.g-1
Compound 4 ended at the assay's limit; the forecaster's own chance of this, stated with the estimate: 35%; middle value at least 1.3-fold (0.12 log units) from the limit.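

No step can be read from compound 3 to compound 4, since both stand at the same limit and neither carries a true number: the limit of > 100 mL.min-1.g-1 in this assay, at which 2 of the 4 values shown sit.

The compounds shown leave open whether 5-methyl-1-propyl-1H-pyrazol-4-yl in place of 3-cyanophenyl on a sulfonyl sulfur changes the intrinsic clearance in this assay at all, and by how much.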